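Removing the ring hydroxy from a related cytotoxic depsipeptide

The source may report more compounds than this note shows. Statements on the series, on what has been measured and on what is new or still open speak of the compounds shown alone.

Compound 2 `CCCC[C@@H](C)C[C@@H](C)C(=O)N(C)[C@@H](C=C(C)C)C(=O)N[C@H](C(=O)N(C)[C@H](C(=O)N1C[C@@H](O)C[C@H]1C(=O)N1C(=O)C=C[C@@H]1C)C(C)C)[C@@H](C)OC(C)=O` and compound 1 `CCCC[C@@H](C)C[C@@H](C)C(=O)N(C)[C@@H](C=C(C)C)C(=O)N[C@H](C(=O)N(C)[C@H](C(=O)N1CCC[C@H]1C(=O)N1C(=O)C=C[C@@H]1C)C(C)C)[C@@H](C)OC(C)=O` differ in one place: hydrogen in place of hydroxy on a saturated ring carbon Measured in a functional assay on NCI-H460 cells (Homo sapiens) for cytotoxicity, read by MTT assay, with a stated time of 48 h (on this read-out lower numbers stand for stronger inhibition and higher numbers for weaker inhibition), compound 2 gives 37 nM, while compound 1 gives 1000 nM, so the loss of the hydroxy produced a 27-fold higher number from compound 2 to compound 1 (1.43 log units; beyond the scatter). Compound 3 `CCCC[C@@H](C)C[C@@H](C)C(=O)N(C)[C@@H](CC(C)C)C(=O)N[C@H](C(=O)N(C)[C@H](C(=O)N1C[C@@H](O)C[C@H]1C(=O)N1C(=O)CC[C@@H]1C)C(C)C)[C@@H](C)OC(C)=O` shares this hydroxy but differs from compound 2 elsewhere; the difference between the two cores is not broken down here. In this assay compound 3 gives 2800 nM. Compound 4 `CCCC[C@@H](C)C[C@@H](C)C(=O)N(C)[C@@H](CC(C)C)C(=O)N[C@H](C(=O)N(C)[C@H](C(=O)N1CCC[C@H]1C(=O)N1C(=O)CC[C@@H]1C)C(C)C)[C@@H](C)OC(C)=O` is made from compound 3 by the same change: hydrogen in place of hydroxy on a saturated ring carbon Since the change and its place match those from compound 2 to compound 1, a comparable weakening is expected, that is a 14-fold higher number from compound 3 to compound 4 (1.15 log units; beyond the scatter), resting on a 27-fold higher number from compound 2 to compound 1 (1.43 log units; beyond the scatter). Compound 4 is therefore estimated to give about 40000 nM in this assay, most likely between 8000 nM and 150000 nM.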

Compound 4, half-maximal inhibitory concentration: 5000 nM
Estimate against measurement, compound 4: 8.0-fold (0.90 log units) above; measured number outside the range, below it.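

In this assay the removal of the hydroxy gives a 1.8-fold higher number from compound 3 to compound 4 (0.25 log units; within the scatter) and so no change that stands out from the scatter on this core. The pairs show that this one change cannot be assumed to have the same size on both cores, but they do not show what sets its size. The size seen on the first core did not carry over to the second: the same change on two cores in this assay, a 27-fold higher number (1.43 log units; beyond the scatter) from compound 2 to compound 1 and a 1.8-fold higher number (0.25 log units; within the scatter) from compound 3 to compound 4, 15-fold (1.18 log units) apart, beyond the scatter of two such steps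

The compounds shown leave open how an amine or a methoxy group in place of the hydroxy would behave on either core. Also open is which of the differences between the two cores matters, as no pair shown separates them.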